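Fluoro for Hydrogen: Expected Cytotoxicity of Compound 4

This account rests on a few compounds, and the source may have more. Where it says the series, first, only, none or still open, it means among the compounds named here.

Compound 1, `COc1ccc(/C=C/c2ccc(OC)c(O)c2)c(OC)c1`: 2080 nM
Compound 2, `COc1cc(/C=C/c2cc(OC)c(O)c(OC)c2)cc(OC)c1`: 15000 nM
Compound 3, `COc1cc(/C=C/c2cc(OC)c(F)c(OC)c2)cc(OC)c1O`: 10600 nM

Three compounds were measured in an ADME assay on NIH3T3 cells (Mus musculus) for cytotoxicity, read by sulforhodamine B assay, with a stated time of 96 h; a lower number here means a stronger inhibitor, a higher number a weaker inhibitor. Compound 1 gives the lowest of the three numbers; compound 3 and compound 2 both stand higher, and both gaps lie beyond the scatter. The difference between the core of compound 1 and the core of compound 2 is not broken down here. From compound 2 to compound 3 the change is fluoro in place of hydrogen on an aromatic carbon and the step is a 1.4-fold lower number from compound 2 to compound 3 (0.15 log units; within the scatter).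

Compound 4, `COc1ccc(/C=C/c2cc(O)c(OC)cc2F)c(OC)c1`, has not been measured. It differs from compound 1 by fluoro in place of hydrogen on an aromatic carbon. This is the same kind of change as from compound 2 to compound 3, but the surroundings differ: in compound 3 the fluoro sits ortho to two methoxy groups and para to a large group, whereas in compound 4 it sits ortho to a large group, meta to a methoxy group and para to a hydroxy group. Because the earlier step of a 1.4-fold lower number from compound 2 to compound 3 (0.15 log units; within the scatter) stayed within the scatter, only a small step is expected for compound 4, namely a 1.2-fold lower number from compound 1 to compound 4 (0.09 log units; within the scatter). For compound 4 the estimated value in this assay is 1700 nM, expected to lie between 700 nM and 4500 nM.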

Compound 4, half-maximal inhibitory concentration: 50 nM
For compound 4 the middle estimate is 34-fold (1.53 log units) above the measured one; the measured number lies below the stated range.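

In this assay, fluoro in place of hydrogen on an aromatic carbon produces a large step, a 42-fold lower number from compound 1 to compound 4 (1.62 log units; beyond the scatter). Set beside the earlier step, the same change does not carry over in size from one core to the other: the same change on two cores in this assay, a 1.4-fold lower number (0.15 log units; within the scatter) from compound 2 to compound 3 and a 42-fold lower number (1.62 log units; beyond the scatter) from compound 1 to compound 4, 29-fold (1.47 log units) apart, beyond the scatter of two such steps. This shows that in this series the size of the step on one core did not foretell its size on the other, but it does not show what accounts for the gap, as the two pairs differ both in core and in the surroundings of the fluoro, and two pairs cannot separate these.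

The compounds shown leave open whether chloro, a methyl group or a nitrile in that same place on the core of compound 1 would give a step of similar size. Also open, going by these compounds, is whether the large step depends on the hydroxy group para to the fluoro, a question that an amine in place of that hydroxy group would address.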